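Swapping chlorines for fluorines on the phenoxy arm

A few compounds are considered here, and "the series" means these few. Any claim that something is new, unique, unknown or untested is made for them only; others in the source may bear on it.

Compound 1, `Cc1cn(C2CCN(Cc3cccc(OC4CCCCC4)c3)CC2)c(=O)[nH]c1=O`, gives 23600 nM in an ADME assay on MRC5 cells (Homo sapiens) for cytotoxicity, read by fluorescence and resazurin assay, with a stated time of 3 days; on this read-out lower numbers stand for stronger inhibition and higher numbers for weaker inhibition.
Compound 2, `Cc1cn(C2CCN(Cc3cccc(Oc4cccc(C(F)(F)F)c4)c3)CC2)c(=O)[nH]c1=O`, gives 12400 nM in this assay.
Compound 3, `Cc1cn(C2CCN(Cc3cccc(Oc4ccc(Cl)c(Cl)c4)c3)CC2)c(=O)[nH]c1=O`, gives 6100 nM in this assay.

Compound 3 stands lowest of the three numbers in this assay: its nearest neighbour is compound 2, with a 2.0-fold lower number from compound 2 to compound 3 (0.31 log units; beyond the scatter), and the furthest is compound 1, with a 3.9-fold lower number from compound 1 to compound 3 (0.59 log units; beyond the scatter). Both steps change the group on the oxygen on the aromatic ring, and both are modest. The step of a 1.9-fold lower number from compound 1 to compound 2 (0.28 log units; within the scatter), between the two other compounds, stays within the scatter.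

Compound 4, `Cc1cn(C2CCN(Cc3cccc(Oc4ccc(F)c(F)c4)c3)CC2)c(=O)[nH]c1=O`, differs from compound 3 in one place: 3,4-difluorophenyl in place of 3,4-dichlorophenyl on an oxygen on an aromatic ring. Among the measured compounds shown here, no measured step exchanges one halogen for another on that phenyl ring, so nothing bears on this change directly. For the measured compounds named here, the only guidance is that every variation of this group so far, from compound 1 to compound 3, has moved the number by a modest amount at most. The expectation is therefore a small shift, if any, with the number for compound 4 more likely to sit above that of compound 3 than below it, as the step of a 2.0-fold higher number from compound 3 to compound 4 (0.29 log units; within the scatter) expresses. Compound 4 is estimated at 12000 nM in this assay, in a range from 5000 nM to 30000 nM.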

Compound 4, half-maximal inhibitory concentration: > 64000 nM
Compound 4: a limit, no number (the forecaster's own chance of this, stated with the estimate: 10%); at least 5.3-fold (0.72 log units) between middle value and limit.
By their numbers in this assay, from the lowest: compound 3; then compounds 2 and 1 (each within the scatter of the next). At a limit, above all of these: compound 4.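

In this assay, among the compounds shown here, the group on the oxygen on the aromatic ring proves able to move the number much further than the earlier compounds showed, and a change of halogen alone is enough to do it: an at least 10-fold higher number from compound 3 to compound 4 (1.02 log units; beyond the scatter). The 3,4-difluorophenyl group also stands clear of the two other groups, with an at least 5.1-fold higher number from compound 2 to compound 4 (0.71 log units; beyond the scatter) and an at least 2.7-fold higher number from compound 1 to compound 4 (0.43 log units; beyond the scatter), so the change from 3,4-dichlorophenyl to 3,4-difluorophenyl does more than undo the modest steps seen before and carries the number past that of the cyclohexyl group. The reading for compound 4 is a limit and not a number, so these three steps give only the least size of each change: the limit of > 64000 nM in this assay, at which 1 of the 4 values shown sits.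

On these data alone, how far compound 4 lies past its limit remains open, and so does whether the large step needs both fluorines or would follow from exchanging a single chlorine. A plain phenyl group, a 3-chlorophenyl or 4-chlorophenyl group, a 3-fluorophenyl or 4-fluorophenyl group and a 3,4-dibromophenyl group on the same oxygen would each help to settle how the number follows the halogen on this ring.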